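The source may report more compounds than this note shows. Statements on the series, on what has been measured and on what is new or still open speak of the compounds shown alone.

The four compounds share one core: compound 1 is `CCOC(=O)c1cnc(NCC2CCCCC2)n2nc(-c3ccco3)nc12`, compound 2 is `CCOC(=O)c1cnc(N(C)C)n2nc(-c3ccco3)nc12`, compound 3 is `CCNc1ncc(C(=O)O)c2nc(-c3ccco3)nn12` and compound 4, not yet measured, is `O=C(O)c1cnc(NCc2ccc(Cl)cc2)n2nc(-c3ccco3)nc12`. In a functional assay on CHO cells for antagonist activity at adenosine receptor A2b (Homo sapiens) (a lower number here means a stronger inhibitor, a higher number a weaker inhibitor), compound 1 gives only a limit, > 10000 nM. In this assay compound 2 likewise gives only a limit, > 10000 nM. Compound 3 in this assay also gives only a limit, > 10000 nM. The step that the two limits leave unreadable from compound 1 to compound 2 is unreadable, both of its ends being limits. Going by the values given here, every value so far sits at the limit of > 10000 nM in this assay, at which 3 of the 3 values shown sit, so no step in the set has a readable size.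

Compound 4 differs from compound 3 by 4-chlorophenyl in place of methyl on a saturated chain carbon bound to a nitrogen on an aromatic ring. Among the compounds with values here, no measured step bears on this change: the only step, from compound 1 to compound 2, alters the same amine substituent but cannot be sized. On the numbers shown, compound 3 stands at the limit with the rest of the set. With nothing pointing either way, compound 4 is expected to give 10000 nM, between 2500 nM and 40000 nM, most likely again as a limit. The step of a number no higher from compound 3 to compound 4 (the limit leaves the size open) is thus expected to be within the scatter or unreadable.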

Compound 4, inhibition constant: > 30000 nM
Compound 4: only a limit was reported; the forecaster's own chance of this, stated with the estimate: 70%; middle value at least 3.0-fold (0.47 log units) away from the limit.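

In this assay compound 4 gives > 30000 nM, which is a limit. Compound 3 also stands at a limit, so the step between compound 3 and compound 4 cannot be read. The compounds shown leave open whether any amine substituent on the shared core gives a readable value in this assay.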